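A few compounds are considered here, and "the series" means these few. Any claim that something is new, unique, unknown or untested is made for them only; others in the source may bear on it.

Compound 1 `Cc1nn(C)c2c1C(c1ccccc1)=NCCN2`: 2.5 mg/kg
Compound 2 `Cc1nn(C)c2c1C(c1ccccc1)=NCCN2C`: 2.5 mg/kg
Compound 3 `Cc1nn(C)c2c1C(c1ccccc1)=NCCN2CCCN(C)C`: > 10 mg/kg

All three compounds share one core and were tested in a functional assay on the whole organism for positive allosteric modulation, with Rattus norvegicus as the target; on this read-out higher numbers stand for an effect only at larger amounts of compound and lower numbers for an effect already at smaller amounts. Compound 1 and compound 2 give numbers that lie within the scatter of each other, as no change at the digits printed from compound 1 to compound 2 (within the scatter) shows. For compound 3 the result is not a number but a limit of the assay, (the limit of > 10 mg/kg in this assay, at which 1 of the 3 values shown sits), so only a range is known for it. Measured against the two others, the difference is real: an at least 4.0-fold higher number from compound 1 to compound 3 (0.60 log units; beyond the scatter) and an at least 4.0-fold higher number from compound 2 to compound 3 (0.60 log units; beyond the scatter) both lie beyond the scatter, and only the 3-(dimethylamino)propyl group on the nitrogen of the aromatic ring separates compound 3 from compound 1.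

Compound 4 `Cc1nn(C)c2c1C(c1ccccc1Cl)=NCCN2CCCN(C)C` differs from compound 3 by chloro in place of hydrogen on an aromatic carbon. Within the data shown here, none of the measured steps touches the phenyl ring: each of them alters the nitrogen of the aromatic ring in a ring or the chain bound to it. Among the measured compounds shown here, no measured step therefore bears on this change, and no step beyond the scatter is expected; the expected step is a number no higher from compound 3 to compound 4 (the limit leaves the size open). Compound 4 is thus estimated at 10 mg/kg, within a range from 3 mg/kg to 30 mg/kg, with a real chance that this assay again reports only a limit.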

Compound 4, minimum effective dose: > 10 mg/kg
Compound 4 was reported as a limit; the forecaster's own chance of this, stated with the estimate: 60%; the middle value sits exactly at the limit.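

In this assay, compound 3 and compound 4 are both reported only as limits, so the step between them cannot be read: the limit of > 10 mg/kg in this assay, at which 2 of the 4 values shown sit.

The compounds shown leave open whether going from phenyl to 2-chlorophenyl changes the dose needed for an effect at all, and in which direction.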